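The source may report more compounds than this note shows. Statements on the series, on what has been measured and on what is new or still open speak of the compounds shown alone.

Compound 1 `Fc1ccc(F)c(/N=N/Nc2ccccc2)c1` and compound 2 `Fc1ccc(F)c(/N=N/Nc2cccc(C(F)(F)F)c2)c1` share one core and differ in a single place. In an ADME assay on MT4 cells (Homo sapiens) for cytotoxicity, read by MTT assay, with a stated time of 96 h (a higher number here means that more compound is tolerated, a lower number that less compound is tolerated), compound 1 gives 100000 nM. Compound 2 gives > 100000 nM in this assay, which is a limit of the measurement and not a number. The change hydrogen in place of trifluoromethyl on an aromatic carbon thus produces a number no higher from compound 2 to compound 1 (the limit leaves the size open), and because of the limit of > 100000 nM in this assay, at which 1 of the 3 values shown sits, the size of that step cannot be read. Compound 3 `CN(C)CCCN(/N=N/c1ccccc1)c1cccc(C(F)(F)F)c1` stands on a different core; how that core differs from the core of compound 2 is not broken down here. In this assay, for the measured compounds named here, compound 3 gives 14000 nM, the lower of the two numbers known, and its gap to compound 1 lies beyond the usual scatter. Compound 4 `CN(C)CCCN(/N=N/c1ccccc1)c1ccccc1` arises from compound 3 by the same change, (hydrogen in place of trifluoromethyl on an aromatic carbon), made on an aromatic carbon of a six-membered aromatic ring of carbon only, meta to a large group. Compound 4 is expected to remain near compound 3, a step of a 1.4-fold higher number from compound 3 to compound 4 (0.15 log units; within the scatter) that rests on compound 3 at 14000 nM and on the unreadable size of a number no higher from compound 2 to compound 1 (the limit leaves the size open). The estimate for compound 4 is 20000 nM, between 7000 nM and 60000 nM.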

Compound 4, half-maximal cytotoxic concentration: 33000 nM
For compound 4 the middle estimate is 1.7-fold (0.22 log units) below the measured one; measured number inside the range.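

In this assay, putting hydrogen in place of trifluoromethyl on the core of compound 3 gives a 2.4-fold higher number from compound 3 to compound 4 (0.37 log units; beyond the scatter), so on this core the change leaves a modest rise in the tolerated concentration. Set beside the same change on the core of compound 1, the result shows no more than this: the same change on two cores in this assay, a number no higher (the limit leaves the size open) from compound 2 to compound 1 and a 2.4-fold higher number (0.37 log units; beyond the scatter) from compound 3 to compound 4; the limit leaves it open whether they differ The pair therefore does not show that the change carries over from one core to the other with the same size or direction, and the step on the core of compound 1 cannot be read, because of a single value: the limit of > 100000 nM in this assay, at which 1 of the 4 values shown sits.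

The compounds shown leave open how a chlorine, a methoxy group or a nitrile on that aromatic carbon would compare with trifluoromethyl and hydrogen on either core. For the compounds shown here, they also leave open whether the step seen from compound 3 to compound 4 would hold with a longer chain in place of the one these two compounds carry.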